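This account rests on a few compounds, and the source may have more. Where it says the series, first, only, none or still open, it means among the compounds named here.

Three compounds have been measured in a functional assay on Hep 3B2 cells (Homo sapiens) for antiproliferative activity, read by MTT assay, with a stated time of 24 h, tested at 0.05 ug/mL; a higher number here means a stronger effect of the compound at the concentration tested, a lower number a weaker effect:

compound 1 `Cc1ccc2nc(C(=O)Nc3c(F)cc(-c4cccc(F)c4)cc3F)c(C)c(O)c2c1` gives 1.52%
compound 2 `CCc1ccc2nc(C(=O)Nc3c(F)cc(-c4cccc(F)c4)cc3F)c(C)c(O)c2c1` gives 5.62%
compound 3 `CCOc1ccc2nc(C(=O)Nc3c(F)cc(-c4cccc(F)c4)cc3F)c(C)c(O)c2c1` gives -0.04%

Compound 3 stands lowest of the three numbers, though all three sit within the scatter of one another: the step of a number 1.6 percentage points lower from compound 1 to compound 3 (within the scatter) and the step of a number 5.7 percentage points lower from compound 2 to compound 3 (within the scatter) are both small, as is a number 4.1 percentage points higher from compound 1 to compound 2 (within the scatter). Compound 4 `Cc1c(C(=O)Nc2c(F)cc(-c3cccc(F)c3)cc2F)nc2ccc(OC(F)(F)F)cc2c1O` differs from compound 3 in one place: trifluoromethyl in place of ethyl on an oxygen on an aromatic ring. For the measured compounds named here, the steps that bear on it are the two swaps at this same aromatic carbon, which moved nothing beyond the scatter. A further change of the same kind is therefore expected to give no step beyond the scatter in this assay. Compound 4 is expected to give 2%, within a range from -8% to 12%. The step expected is a number 2 percentage points higher from compound 3 to compound 4 (within the scatter).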

Compound 4, a percentage reported as inhibition, at one concentration (the size of the read-out at that concentration, not a potency): 1.05%
Compound 4: the middle estimate sits 1 percentage points above what was measured; measured number inside the range.
By their numbers in this assay, from the lowest: compounds 3, 4, 1 and 2 (each within the scatter of the next).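

At this aromatic carbon, trifluoromethoxy in place of ethoxy brings fluorine into the group and still gives only a number 1.1 percentage points higher from compound 3 to compound 4 (within the scatter) in this assay, while trifluoromethoxy in place of the plain chains gives a number 4.6 percentage points lower from compound 2 to compound 4 (within the scatter) and a number 0.5 percentage points lower from compound 1 to compound 4 (within the scatter). Methyl, ethyl, ethoxy and trifluoromethoxy at this carbon thus all lie within the scatter of one another at this one concentration. Nothing available explains this result. As far as these compounds go, whether an amine, a carboxylic acid or a longer chain at this carbon would give a step beyond the scatter stays open. So does how these compounds behave at other concentrations.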